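The source may hold more compounds than are shown below. What is called first, only, known or untested is meant among the compounds shown, and "the series" means these compounds.

Working notes on the series.

Of the compounds shown here, three with a shared core have been measured in a functional assay on HL-60 cells (Homo sapiens) for inhibition, read by MTT assay, with a stated time of 48 h, tested at 10 uM; a higher number here means more inhibition of growth at the concentration tested, a lower number less inhibition of growth. Compound 1 `Cc1cc(=O)c2c(O)cc(O)c([C@H]3CCN(C)C[C@H]3OC(=O)c3ccco3)c2o1` gives 22% in this assay. Compound 2 `Cc1cc(=O)c2c(O)c(CN3CCC(N4CCCCC4)CC3)c(O)c([C@H]3CCN(C)C[C@H]3O)c2o1` gives 34% in this assay. Compound 3 `Cc1oc2c([C@H]3CCN(C)C[C@H]3O)c(O)cc(O)c2c(=O)c1C(O)c1cccc(Cl)c1` gives 22% in this assay; at the digits given this is level with compound 1, the two together forming the lowest pair of the three numbers, while compound 2 sits a step higher that goes beyond the scatter. For the measured compounds named here, no pair of measured compounds differs in a single place, so no measured single-point step is available.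

Compound 4 `Cc1oc2c([C@H]3CCN(C)C[C@H]3O)c(O)cc(O)c2c(=O)c1C(O)c1cccc(Cl)c1Cl` is not yet measured in this assay. It differs from compound 3 in one place: chloro in place of hydrogen on an aromatic carbon. Nothing in the measured set shows what such a change does, so the expectation leans on compound 3 alone, at 22% in this assay. The expected step of a number 3 percentage points higher from compound 3 to compound 4 (within the scatter) is small, not beyond the scatter. For compound 4 the estimated value in this assay is 25%, with a range from 12% to 40%.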

Compound 4, percent growth inhibition at one concentration: 12%
Compound 4: the middle estimate sits 13 percentage points above what was measured, and the stated range covers the measured number.
By their numbers in this assay, from the lowest: compounds 4, 1 and 3 (each within the scatter of the next); then compound 2.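

For the compounds shown here, the step of a number 10 percentage points lower from compound 3 to compound 4 (within the scatter) in this assay is the first single-place comparison, and it belongs to the change from 3-chlorophenyl to 2,3-dichlorophenyl. Chloro in place of hydrogen at this aromatic carbon, ortho to a chloro group and ortho to a large group, therefore does not separate the two compounds in this read-out, though the step reaches the edge of the scatter. Nothing in hand bears on what lies behind this step.

Going by these compounds, it remains open whether an amine or a methoxy group on this same aromatic carbon would give a step beyond the scatter. On these data alone, it is also open whether a chloro group here would give a similar step in a compound carrying the piperidinylpiperidine side chain of compound 2.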